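A few compounds are considered here, and "the series" means these few. Any claim that something is new, unique, unknown or untested is made for them only; others in the source may bear on it.

Compound 1, `CNc1nc(Nc2ccc(C)c([N+](=O)[O-])c2)ncc1C(=O)Nc1cc(NC(=O)c2ccc(OC)c(OC)c2)ccc1C`, gives 680 nM in a functional assay on K562 cells (Homo sapiens) for antiproliferative activity, read by CellTiter-Glo and CCK-8 assay, with a stated time of 72 h; a lower number here means a stronger inhibitor of growth, a higher number a weaker inhibitor of growth. Compound 2, `CNc1nc(Nc2ccc(C)c([N+](=O)[O-])c2)ncc1C(=O)Nc1cc(NC(=O)c2cc(OC)cc(OC)c2)ccc1C`, gives 1070 nM in this assay. Compound 3, `CNc1nc(Nc2ccc(C)c(N)c2)ncc1C(=O)Nc1cc(NC(=O)c2ccc(OC)c(OC)c2)ccc1C`, gives 380 nM in this assay.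

Two changes run through this small set. The first, (3,5-dimethoxyphenyl in place of 3,4-dimethoxyphenyl on a carbonyl carbon), is made once between measured compounds and there gives a 1.6-fold higher number from compound 1 to compound 2 (0.20 log units; within the scatter). The second, (amino in place of nitro on an aromatic carbon), is the difference between the two cores and gives a 1.8-fold lower number from compound 1 to compound 3 (0.25 log units; within the scatter). Compound 3 has the lowest number of the three, though its gap to compound 1 lies within the scatter; only its gap to compound 2 lies beyond it.

Compound 4, `CNc1nc(Nc2ccc(C)c(N)c2)ncc1C(=O)Nc1cc(NC(=O)c2cc(OC)cc(OC)c2)ccc1C`, has not been measured in this assay. It differs from compound 3 by 3,5-dimethoxyphenyl in place of 3,4-dimethoxyphenyl on a carbonyl carbon, the same change as that from compound 1 to compound 2, at the same place. That earlier step gave a 1.6-fold higher number from compound 1 to compound 2 (0.20 log units; within the scatter). The step from compound 3 to compound 4 is therefore expected to resemble it, and is estimated at a 1.6-fold higher number from compound 3 to compound 4 (0.20 log units; within the scatter). Since this rests on a single earlier step, itself within the scatter, the expectation is loose. For compound 4 the estimated value in this assay is 600 nM, with a range from 300 nM to 1300 nM.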

Compound 4, concentration for 50% growth inhibition: 230 nM
Compound 4: the middle estimate sits 2.6-fold (0.42 log units) above what was measured; measured number below the stated range.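

In this assay, placing 3,5-dimethoxyphenyl where 3,4-dimethoxyphenyl stood on the core of compound 3 gives a 1.7-fold lower number from compound 3 to compound 4 (0.22 log units; within the scatter), and this step and its earlier counterpart on the core of compound 1 do not differ beyond the scatter: the same change on two cores in this assay, a 1.6-fold higher number (0.20 log units; within the scatter) from compound 1 to compound 2 and a 1.7-fold lower number (0.22 log units; within the scatter) from compound 3 to compound 4, 2.6-fold (0.41 log units) apart, within the scatter of two such steps The amino in place of nitro change, read on the 3,5-dimethoxyphenyl compounds, gives a 4.7-fold lower number from compound 2 to compound 4 (0.67 log units; beyond the scatter), and this step too stands level with its earlier counterpart within the scatter: the same change on two cores in this assay, a 1.8-fold lower number (0.25 log units; within the scatter) from compound 1 to compound 3 and a 4.7-fold lower number (0.67 log units; beyond the scatter) from compound 2 to compound 4, 2.6-fold (0.41 log units) apart, within the scatter of two such steps So neither change is shown to depend on the core, but with one pair per core and two cores in all, this does not establish that either change carries over unchanged, and the dimethoxyphenyl steps, each within the scatter, do not show that this change has any effect of its own on either core.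

The compounds shown leave open how a single methoxy group, a fluorine or a pyridine ring on the same carbonyl carbon would behave on these two cores. They also leave open whether the amino in place of nitro step would hold for an acetamide or a hydroxyl group.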